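The source may hold more compounds than are shown below. What is called first, only, known or untested is meant among the compounds shown, and "the series" means these compounds.

Measured so far:
- compound 1 `CCOc1cc(/C=C/C(=O)C(=Cc2ccc(OC)c(OC)c2)C(=O)/C=C/c2ccc(O)c(OCC)c2)ccc1O`: 42000 nM
- compound 2 `CCOc1cc(C=C(C(=O)/C=C/c2ccc(O)c(OCC)c2)C(=O)/C=C/c2ccc(O)c(OCC)c2)ccc1O`: 1360 nM

In a functional assay on DLD-1 cells (Homo sapiens) for cytotoxicity, read by MTT assay (a lower number here means a stronger inhibitor, a higher number a weaker inhibitor), compound 2 holds the lower of the two numbers, at 1360 nM. Compound 3 `CCOc1cc(/C=C/C(=O)C(=Cc2ccc(O)c(O)c2)C(=O)/C=C/c2ccc(O)c(OCC)c2)ccc1O` differs from it by hydrogen in place of ethyl on an oxygen on an aromatic ring, turning 3-ethoxy-4-hydroxyphenyl into 3,4-dihydroxyphenyl. Within the data shown here, only one measured step touches this group: a 31-fold lower number from compound 1 to compound 2 (1.49 log units; beyond the scatter), large and beyond the scatter. That step removed 3,4-dimethoxyphenyl, which compound 3 does not carry, so it shows sensitivity here but gives no direction for this change. The expected change is a 1.3-fold higher number from compound 2 to compound 3 (0.12 log units; within the scatter), with nothing beyond the scatter foreseen. For compound 3 the estimated value is 1800 nM, with an expected range of 400 nM to 9000 nM.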

Compound 3, half-maximal inhibitory concentration: 5100 nM
Compound 3: middle estimate off by 2.8-fold (0.45 log units), on the low side; the range from low to high includes it.
By their numbers in this assay, from the lowest: compound 2; then compound 3; then compound 1.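

In this assay, the ethyl on this oxygen is not interchangeable with hydrogen: the change gives a 3.8-fold higher number from compound 2 to compound 3 (0.57 log units; beyond the scatter). 3,4-Dihydroxyphenyl in place of 3,4-dimethoxyphenyl still gives an 8.2-fold lower number from compound 1 to compound 3 (0.92 log units; beyond the scatter), so from the lowest number the three groups run 3-ethoxy-4-hydroxyphenyl, 3,4-dihydroxyphenyl, 3,4-dimethoxyphenyl. Nothing available explains these differences.

On these data alone, it remains open whether a longer chain, such as propyl, on this oxygen would lower or raise the number. As far as these compounds go, how an amine in place of the hydroxy would read is also open.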